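Oxan-4-yl for Methyl: Expected Permeability of Compound 4

This account rests on a few compounds, and the source may have more. Where it says the series, first, only, none or still open, it means among the compounds named here.

Compound 1 `Cn1cc(-c2nc3c(-c4ccc(CNC(=O)c5nc(C(C)(C)C)no5)c(F)c4)ccnc3[nH]2)cn1`: 11 10^-6 cm/s
Compound 2 `Cn1cc(-c2nc3c(-c4ccc(CNC(=O)c5ccc(C(C)(C)C)cn5)c(F)c4)ccnc3[nH]2)cn1`: 0.3 10^-6 cm/s
Compound 3 `Cn1cc(-c2nc3c(-c4ccc(CNC(=O)N5CC(OC(C)(C)C)C5)c(F)c4)ccnc3[nH]2)cn1`: 0.4 10^-6 cm/s

In an ADME assay on Caco-2 cells (Homo sapiens) for permeability, in the apical to basolateral direction (on this read-out higher numbers stand for higher permeability and lower numbers for lower permeability), compound 1 stands highest of the three measured compounds. The two steps away from it are both large: a 37-fold lower number from compound 1 to compound 2 (1.56 log units; beyond the scatter) and a 28-fold lower number from compound 1 to compound 3 (1.44 log units; beyond the scatter). Each of those steps changes the group on the carbonyl carbon. Compound 4 `CC(C)(C)c1noc(C(=O)NCc2ccc(-c3ccnc4[nH]c(-c5cnn(C6CCOCC6)c5)nc34)cc2F)n1` differs from compound 1 at a different place: oxan-4-yl in place of methyl on an aromatic nitrogen. For the measured compounds named here, no measured step touches that position, so the two large steps give no guidance for this change, and the expectation can rest only on the value of compound 1. Compound 4 is therefore expected to stay close to compound 1, a 1.2-fold lower number from compound 1 to compound 4 (0.09 log units; within the scatter), with a wide range around it. The estimated value of compound 4 in this assay is 9 10^-6 cm/s, between 3 10^-6 cm/s and 25 10^-6 cm/s.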

Compound 4, apparent permeability: 0.8 10^-6 cm/s
Estimate against measurement, compound 4: 11-fold (1.05 log units) above; measured number below the stated range.
By their numbers in this assay, from the lowest: compounds 2, 3 and 4 (each within the scatter of the next, the first and the last beyond it); then compound 1.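

In this assay, for the compounds shown here, oxan-4-yl in place of methyl on an aromatic nitrogen gives a 14-fold lower number from compound 1 to compound 4 (1.14 log units; beyond the scatter) and is a large step, so this position, which no earlier compound varied, matters as much as the carbonyl carbon's group did. The step alone cannot separate the effect of the added ring from that of its oxygen, since both enter together. Nothing available gives a reason for this step.

Going by these compounds, whether ethyl or piperidin-4-yl on that nitrogen would stay nearer compound 1 remains open. So does whether this change would give a similar step with the other groups on the carbonyl carbon.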